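The source may report more compounds than this note shows. Statements on the series, on what has been measured and on what is new or still open speak of the compounds shown alone.

Measured compounds in an ADME assay on Vero cells (Chlorocebus sabaeus) for cytotoxicity, with a stated time of 3 days; a lower number here means that less compound is tolerated, a higher number that more compound is tolerated:
compound 1 `CC(C)(C)OC(=O)NOc1nc(N)nc2c1ncn2[C@@H]1O[C@H](CO)[C@@H](O)[C@@]1(C)O` gives > 100000 nM, a limit of the assay.
compound 2 `CONc1nc(N)nc2c1ncn2[C@@H]1O[C@H](CO)[C@@H](O)[C@@]1(C)O` gives > 100000 nM, a limit of the assay.
compound 3 `COc1nc(ONC(=O)OCc2ccccc2)nc2c1ncn2[C@@H]1O[C@H](CO)[C@@H](O)[C@@]1(C)O` gives > 100000 nM, a limit of the assay.

Compound 3 therefore stands at a limit only, and the two further values shown are limits as well, so no ordering among the three compounds can be read. Among the measured compounds shown here, the single measured step, a step that the two limits leave unreadable from compound 1 to compound 2, carries no readable size; the limit of > 100000 nM in this assay, at which 3 of the 3 values shown sit, covers every value shown, and nothing in this assay has yet been distinguished from anything else.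

Compound 4 `COc1nc(OC)c2ncn([C@@H]3O[C@H](CO)[C@@H](O)[C@@]3(C)O)c2n1` differs from compound 3 by methyl in place of (benzyloxycarbonyl)amino on an oxygen on an aromatic ring. For the measured compounds named here, no measured step addresses this change, and the one step that exists is unreadable, so there is no measured size to carry over. With every value in the series at the limit, compound 4 is expected to sit there too; the expected step is a number no higher from compound 3 to compound 4 (the limit leaves the size open), none beyond the scatter. Compound 4 is estimated at 100000 nM in this assay, with a range of 40000 nM to 300000 nM.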

Compound 4, half-maximal cytotoxic concentration: > 100000 nM
Compound 4 ended at the assay's limit (the forecaster's own chance of this, stated with the estimate: 80%); the middle value sits exactly at the limit.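

Among the compounds shown here, compound 3 and compound 4 both stand at a limit of the assay, so the step between them cannot be read and this result adds no new step: the limit of > 100000 nM in this assay, at which 4 of the 4 values shown sit.

In this assay the compounds shown leave open how these four compounds rank against one another, and whether any change to the shared core gives a value that can be read as a number.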